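Shortening One Chain by a Single Carbon

The source may hold more compounds than are shown below. What is called first, only, known or untested is meant among the compounds shown, and "the series" means these compounds.

Measured so far:
compound 1, `O=c1sc2ccccc2n1CCCCCCN1CCN(CCCCCCn2c(=O)sc3ccccc32)CC1`: 24300 nM
compound 2, `O=c1oc2ccccc2n1CCCCCCN1CCN(CCCCCn2c(=O)oc3ccccc32)CC1`: 22500 nM

In an ADME assay on BT-549 cells (Homo sapiens) for cytotoxicity, read by neutral red uptake, with a stated time of 48 h (on this read-out higher numbers stand for weaker inhibition and lower numbers for stronger inhibition), compound 1 gives 24300 nM. Among the measured compounds shown here, the only other value comes from compound 2, which in this assay gives 22500 nM, and the two numbers sit within the usual scatter of each other, so nothing separates them. Compound 3, `O=c1sc2ccccc2n1CCCCCCN1CCN(CCCCCn2c(=O)sc3ccccc32)CC1`, has not been measured. It differs from compound 1 in one place: a group of 10 heavy atoms (7 carbon, 1 nitrogen, 1 oxygen, 1 sulfur; one five-membered aromatic ring with 2 hetero atoms, one six-membered aromatic ring of carbon only) in place of a group of 11 heavy atoms (8 carbon, 1 nitrogen, 1 oxygen, 1 sulfur; one five-membered aromatic ring with 2 hetero atoms, one six-membered aromatic ring of carbon only), on a saturated chain carbon, five bonds along the chain from an amine nitrogen in a ring. For the measured compounds named here, the pair of compound 1 and compound 2 carries two changes at once and so gives no clean step for this one alteration; compound 2 with its shorter chain nonetheless lands where compound 1 does. The expectation for compound 3 is therefore a step of a 1.1-fold lower number from compound 1 to compound 3 (0.04 log units; within the scatter) that stays within the scatter. Compound 3 is estimated at 22000 nM, with a range from 11000 nM to 45000 nM.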

Compound 3, half-maximal inhibitory concentration: 19600 nM
Compound 3: the middle estimate sits 1.1-fold (0.05 log units) above what was measured; the range from low to high includes it.
By their numbers in this assay, from the lowest: compounds 3, 2 and 1 (each within the scatter of the next).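

Among the compounds shown here, compound 1 and compound 3 differ in one place only, so this pair gives the first clean reading of a group of 10 heavy atoms in place of a group of 11 heavy atoms, on a saturated chain carbon, five bonds along the chain from an amine nitrogen in a ring: in this assay the step is a 1.2-fold lower number from compound 1 to compound 3 (0.09 log units; within the scatter). With the rest of the structure held fixed, removing this single chain carbon therefore leaves no change that can be told apart from the scatter. The data shown offer no measurement that bears on this result.

The compounds shown leave open whether a longer chain at this position would read the same way. They also leave open how a hydroxyl group or an amine on this chain would read.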